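Chloro and methyl additions in a cytotoxicity series

The source may report more compounds than this note shows. Statements on the series, on what has been measured and on what is new or still open speak of the compounds shown alone.

Compound 1 `O=C(NOCc1ccccc1Cl)c1cn(-c2ccccc2)nc1-c1ccccc1` gives 82100 nM in an ADME assay on HEK-293T cells (Homo sapiens) for antiproliferative activity, read by MTT assay, with a stated time of 48 h, in the presence of a further agent that is not named here; a lower number here means that less compound is tolerated, a higher number that more compound is tolerated. Compound 2 `O=C(NOCc1ccc(Cl)cc1Cl)c1cn(-c2ccccc2)nc1-c1ccccc1` gives 40200 nM in this assay. Compound 3 `Cc1ccc(-c2nn(-c3ccccc3)cc2C(=O)NOCc2ccccc2Cl)cc1` gives 38700 nM in this assay.

Compound 2 differs from compound 1 by chloro in place of hydrogen on an aromatic carbon; the step is a 2.0-fold lower number from compound 1 to compound 2 (0.31 log units; beyond the scatter). Compound 3 differs from compound 1 by methyl in place of hydrogen on an aromatic carbon; the step is a 2.1-fold lower number from compound 1 to compound 3 (0.33 log units; beyond the scatter). The values of compound 2 and compound 3 lie within the scatter of each other, so nothing separates them.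

Compound 4 `Cc1ccc(-c2nn(-c3ccccc3)cc2C(=O)NOCc2ccc(Cl)cc2Cl)cc1` is not yet measured. Among the compounds with values here, it differs from compound 3 by chloro in place of hydrogen on an aromatic carbon, the same change as the one from compound 1 to compound 2, and the surroundings of the place are described in the same words for both pairs. The cores of the two pairs differ as told by methyl in place of hydrogen on an aromatic carbon.

Within the data shown here, compound 4 is therefore expected to show a step of about a 2.0-fold lower number from compound 3 to compound 4 (0.31 log units; beyond the scatter) in this assay, because the only measured instance of this change gave a 2.0-fold lower number from compound 1 to compound 2 (0.31 log units; beyond the scatter), and the same kind of step is assumed to carry over to the core of compound 3. The estimate for compound 4 is 19000 nM, with a range from 9500 nM to 40000 nM.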

Compound 4, half-maximal cytotoxic concentration: 39600 nM
The estimate for compound 4 lay 2.1-fold (0.32 log units) below the measured number; the measured number falls inside the stated range.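

In this assay, chloro in place of hydrogen, which turns the 2-chlorobenzyl group into the 2,4-dichlorobenzyl group on the core of compound 3, gives a 1.0-fold higher number from compound 3 to compound 4 (0.01 log units; within the scatter), and methyl in place of hydrogen on the core of compound 2 gives a 1.0-fold lower number from compound 2 to compound 4 (0.01 log units; within the scatter). The chloro step on the two cores cannot be told apart from a single shared step, so a real difference between the cores is not shown: the same change on two cores in this assay, a 2.0-fold lower number (0.31 log units; beyond the scatter) from compound 1 to compound 2 and a 1.0-fold higher number (0.01 log units; within the scatter) from compound 3 to compound 4, 2.1-fold (0.32 log units) apart, within the scatter of two such steps. Within the data shown here, the methyl change reads the same way, and with only one pair of cores for each change, the series neither establishes that a step carries over nor shows that it fails to: the same change on two cores in this assay, a 2.1-fold lower number (0.33 log units; beyond the scatter) from compound 1 to compound 3 and a 1.0-fold lower number (0.01 log units; within the scatter) from compound 2 to compound 4, 2.1-fold (0.32 log units) apart, within the scatter of two such steps.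

The compounds shown leave open how a methoxy group or an amine in the place of the added chloro would read in this assay. They also leave open whether a longer chain in the place of the methyl group would behave like methyl on either core.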